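A Trifluoromethyl Swap Repeated on a Second Core

The source may hold more compounds than are shown below. What is called first, only, known or untested is meant among the compounds shown, and "the series" means these compounds.

Measured in a functional assay on the whole organism (strain Albino Swiss CD1) with Mus musculus as the target, in the maximal electroshock model; on this read-out lower numbers stand for an effect already at smaller amounts and higher numbers for an effect only at larger amounts of compound:
Compound 1, `CCC(C(=O)NCc1ccccc1)N1C(=O)CCC1=O`: 73.3 mg/kg
Compound 2, `CCC(C(=O)NCc1ccc(C(F)(F)F)cc1)N1C(=O)CCC1=O`: 69.4 mg/kg
Compound 3, `CC1CC(=O)N(C(C)C(=O)NCc2ccccc2)C1=O`: 106 mg/kg

Compound 1 and compound 2 share one core and differ in a single place: trifluoromethyl in place of hydrogen on an aromatic carbon. In this assay this gave a 1.1-fold lower number from compound 1 to compound 2 (0.02 log units; within the scatter), so the two compounds cannot be told apart on this read-out. Compound 3 is built on a second core; it contains the same atoms as compound 1, joined differently, and the difference between the two cores is not broken down here. In this assay compound 3 gives 106 mg/kg, which sits within the scatter of compound 1 and of compound 2 alike, so nothing separates the three measured compounds on this read-out.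

Compound 4, `CC1CC(=O)N(C(C)C(=O)NCc2ccc(C(F)(F)F)cc2)C1=O`, has not yet been measured. It relates to compound 3 exactly as compound 2 relates to compound 1: trifluoromethyl in place of hydrogen on an aromatic carbon. The place of the change is the same in both pairs, word for word, so this is the same change, made on the other core. Because the first time round this change gave a 1.1-fold lower number from compound 1 to compound 2 (0.02 log units; within the scatter), the estimated step this time is a 1.1-fold lower number from compound 3 to compound 4 (0.03 log units; within the scatter). On that basis compound 4 is expected to give 100 mg/kg in this assay, with the estimate spanning from 55 mg/kg to 180 mg/kg.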

Compound 4, dose for half-maximal effect: > 150 mg/kg
Compound 4 gave a limit, no number; the forecaster's own chance of this, stated with the estimate: 10%; at least 1.5-fold (0.17 log units) between middle value and limit.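

In this assay compound 4 gives > 150 mg/kg, which is a limit of the assay and not a number. Going by these compounds, on the second core, trifluoromethyl in place of hydrogen on an aromatic carbon gives an at least 1.4-fold higher number from compound 3 to compound 4 (0.15 log units; that floor lies within the scatter), and this is a floor rather than a measured size, so the real step remains unknown. The result therefore shows neither that this change carries over from one core to the other nor that it behaves differently there, and setting the two steps side by side leaves that question undecided: the same change on two cores in this assay, a 1.1-fold lower number (0.02 log units; within the scatter) from compound 1 to compound 2 and an at least 1.4-fold higher number (0.15 log units; that floor lies within the scatter) from compound 3 to compound 4; the limit leaves it open whether they differ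

The compounds shown have only hydrogen or trifluoromethyl at this place on the aromatic ring, so they leave open how a chlorine atom, a methoxy group or a nitrile in the same place would read on either core. They also leave open whether an amine or a carboxylic acid there would give a true number on the second core, which would allow a step to be compared in full with the one on the first core.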